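A few compounds are considered here, and "the series" means these few. Any claim that something is new, unique, unknown or untested is made for them only; others in the source may bear on it.

In a functional assay on NCI-H460 cells (Homo sapiens) for inhibition, read by sulforhodamine B assay, with a stated time of 48 h (on this read-out lower numbers stand for stronger inhibition of growth and higher numbers for weaker inhibition of growth), compound 1 `O=C(Nc1cccc(-n2cc(-c3ccncc3)c(-c3ccc(Cl)c(O)c3)n2)c1)Nc1cccc(C(F)(F)F)c1` gives 29000 nM. Compound 2 `COc1cc(-c2nn(-c3cccc(NC(=O)Nc4ccc(Cl)c(Cl)c4)c3)cc2-c2ccncc2)ccc1Cl` reaches only a limit of the assay, > 50000 nM. Within the data shown here, compound 3 `COc1cc(-c2nn(-c3cccc(NC(=O)Nc4cccc(C(F)(F)F)c4)c3)cc2-c2ccncc2)ccc1Cl` gives 3530 nM, the lowest number so far. Compound 4 `COc1cc(-c2nn(-c3cccc(NC(=O)c4ccccc4)c3)cc2-c2ccncc2)ccc1Cl` has phenyl in place of (3-(trifluoromethyl)phenyl)amino on a carbonyl carbon. The closest guide is the large change seen when the group on the amide-type nitrogen was exchanged, an at least 14-fold lower number from compound 2 to compound 3 (1.15 log units; beyond the scatter). The other measured change, an 8.2-fold lower number from compound 1 to compound 3 (0.91 log units; beyond the scatter), was modest and lies elsewhere in the molecule, so it bears less on this one. Removing the group that compound 3 carries there should therefore push the number up in this assay, by a modest to large amount. The step expected here is a 4.2-fold higher number from compound 3 to compound 4 (0.63 log units; beyond the scatter). For compound 4 the estimated value is 15000 nM, with an expected range from 5000 nM to 45000 nM.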

Compound 4, concentration for total growth inhibition: > 100000 nM
Compound 4 gave a limit, no number (the forecaster's own chance of this, stated with the estimate: 25%); middle value at least 6.6-fold (0.82 log units) away from the limit.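

In this assay, among these compounds, the earlier compounds showed only that the ring on the amino nitrogen matters; this change removes the amino nitrogen as well, giving an at least 28-fold higher number from compound 3 to compound 4 (1.45 log units; beyond the scatter). Compound 4 gives > 100000 nM, which is a limit of the assay and not a number. Compound 2 also sits at a limit, so the step between compound 2 and compound 4 cannot be read.

On these data alone, the amino nitrogen and the trifluoromethyl group left in a single change, so their separate contributions remain open. As far as these compounds go, a plain phenylamino group on the carbonyl carbon would keep the nitrogen without the trifluoromethyl, and how it would read is unknown.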